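Removing the chloro from compound 1

A few compounds are considered here, and "the series" means these few. Any claim that something is new, unique, unknown or untested is made for them only; others in the source may bear on it.

Compound 1 `O=c1c(CSC(=S)N2CCCCC2)coc2cc(Cl)ccc12` carries a piperidin-1-yl on the thiocarbonyl carbon and gives 850 nM in a functional assay on LM7 cells (Homo sapiens) for antiproliferative activity, read by MTT assay, with a stated time of 72 h (a higher number here means a weaker inhibitor, a lower number a stronger inhibitor), the lowest number of the three measured. Compound 2 `O=c1c(CSC(=S)N2CCOCC2)coc2cc(Cl)ccc12` gives 6200 nM and compound 3 `O=c1c(CSC(=S)N2CCCC2)coc2cc(Cl)ccc12` gives 2600 nM. The measured steps all change the amine on the thiocarbonyl carbon: a 7.3-fold higher number from compound 1 to compound 2 (0.86 log units; beyond the scatter), a 3.1-fold higher number from compound 1 to compound 3 (0.49 log units; beyond the scatter) and a 2.4-fold lower number from compound 2 to compound 3 (0.38 log units; beyond the scatter).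

Compound 4 `O=c1c(CSC(=S)N2CCCCC2)coc2ccccc12` differs from compound 1 in another place: hydrogen in place of chloro on an aromatic carbon, on an aromatic carbon of the six-membered carbon ring that is part of the fused system, meta and para to the fused ring. Going by the values given here, none of the measured steps touches the chloro, so no step bears directly on this change; the amine steps only show that the series is sensitive to modest changes. The expected step is therefore uncertain, and a small loss or no change beyond the scatter seems most likely, with compound 4 expected to give 1500 nM, between 500 nM and 5000 nM, an expected 1.8-fold higher number from compound 1 to compound 4 (0.25 log units; within the scatter).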

Compound 4, half-maximal inhibitory concentration: 4600 nM
For compound 4 the middle estimate is 3.1-fold (0.49 log units) below the measured one, within the range that was stated.
By their numbers in this assay, from the lowest: compound 1; then compounds 3, 4 and 2 (each within the scatter of the next, the first and the last beyond it).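

Replacing the chloro with hydrogen gives a 5.4-fold higher number from compound 1 to compound 4 (0.73 log units; beyond the scatter) in this assay and shows that this substituent, on an aromatic carbon meta to a fused ring and para to a fused ring, is not silent. The series therefore responds at this position as well as at the amine on the thiocarbonyl carbon, and with piperidin-1-yl held fixed, the chloro compound has the lower number. No measurement at hand accounts for this loss on removing the chloro.

The hydrogen form is shown only with piperidin-1-yl, so it stays open whether the chloro has a similar effect with morpholin-4-yl or pyrrolidin-1-yl on the thiocarbonyl carbon. Also open, going by these compounds, is whether fluoro, bromo or methoxy on this carbon would match the chloro.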